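Removing the nitro group from compound 1

The source may hold more compounds than are shown below. What is called first, only, known or untested is meant among the compounds shown, and "the series" means these compounds.

Compound 1 `CC1=C(C(=O)OCc2ccccn2)C(c2ccc([N+](=O)[O-])cc2)C2=C(CCCC2=O)N1` has the highest partition coefficient of the three measured compounds in a physicochemical assay for lipophilicity, measured as octanol-water partition (a lower number here means a more polar compound, a higher number a more lipophilic compound), at 1.88. Compound 2 `CC1=C(C(=O)OCc2cccnc2)C(c2ccc([N+](=O)[O-])cc2)C2=C(CCCC2=O)N1` sits lower, at 1.51, and compound 3 `CC1=C(C(=O)OCc2cccnc2)C(c2cccc(O)c2)C2=C(CCCC2=O)N1` lower still, at 1.21. The step from compound 1 to compound 2 is a number 0.37 log units lower from compound 1 to compound 2 (beyond the scatter), and the step from compound 2 to compound 3 is a number 0.30 log units lower from compound 2 to compound 3 (within the scatter).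

Compound 4 `CC1=C(C(=O)OCc2ccccn2)C(c2ccccc2)C2=C(CCCC2=O)N1` differs from compound 1 in one place: hydrogen in place of nitro on an aromatic carbon. Within the data shown here, no measured step follows this exact change. The nearest relative is the step at the same saturated ring carbon, a number 0.30 log units lower from compound 2 to compound 3 (within the scatter), in which a 4-nitrophenyl gave way to a 3-hydroxyphenyl and the number moved within the scatter. With the nitro group leaving and only hydrogen entering, a small rise in this assay is expected for compound 4, estimated as a number 0.27 log units higher from compound 1 to compound 4 (within the scatter), though a result within the scatter would not surprise. Compound 4 is therefore expected to give about 2.15, within 1.75 to 2.55.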

Compound 4, partition coefficient: 2.72
Estimate against measurement, compound 4: 0.57 log units below; measured number above the stated range.
By their numbers in this assay, from the lowest: compounds 3 and 2 (each within the scatter of the next); then compound 1; then compound 4.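

Replacing 4-nitrophenyl with phenyl, with hydrogen in place of nitro on the aromatic carbon, gives a clear step in this assay (a number 0.84 log units higher from compound 1 to compound 4 (beyond the scatter)). Among these compounds, the earlier change at the same saturated ring carbon, from 4-nitrophenyl to 3-hydroxyphenyl, put another group on the ring and stayed within the scatter (a number 0.30 log units lower from compound 2 to compound 3 (within the scatter)), so this is the first sign that a change at this position can move the number beyond the scatter. Nothing available accounts for the size of the step.

Open, as far as these compounds go, is where an amine or a carboxylic acid on that aromatic carbon would fall in this assay relative to compound 1 and compound 4. Also open, from the compounds shown here alone, is whether removing the nitro group gives a step of similar size when the pyridin-3-yl group of compound 2 stands in place of pyridin-2-yl.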